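A few compounds are considered here, and "the series" means these few. Any claim that something is new, unique, unknown or untested is made for them only; others in the source may bear on it.

Measured so far in an assay on isolated protein for inhibition of Polyunsaturated fatty acid 5-lipoxygenase (Homo sapiens); on this read-out higher numbers stand for weaker inhibition and lower numbers for stronger inhibition:

compound 1 `CCOC(=O)c1c(Nc2ccc(C)cc2)[nH]c2ccc(O)cc12` — 5000 nM
compound 2 `CCOC(=O)c1c(NC(C)c2ccccc2)[nH]c2ccc(O)cc12` — 3000 nM

Two numbers only. Compound 2 carries the lower of the two, but the step of a 1.7-fold lower number from compound 1 to compound 2 (0.22 log units; within the scatter) is within the scatter, so compound 2 and compound 1 are not separable on this read-out; compound 2 simply stands within the scatter of compound 1.

Next in line is compound 3 `CCOC(=O)c1c(NC(C)c2ccccc2)[nH]c2ccccc12`. Relative to compound 2 the change is hydrogen in place of hydroxy on an aromatic carbon. Within the data shown here, the one measured step, a 1.7-fold lower number from compound 1 to compound 2 (0.22 log units; within the scatter), concerns the group on the ring nitrogen and leaves the hydroxy untouched, so no measured step bears directly on removing the hydroxy; the series gives no read on this position at all. Among the measured compounds shown here, with the only available step being within the scatter and unrelated in place, the working expectation for compound 3 is no step beyond the scatter in this assay, estimated as a 1.7-fold higher number from compound 2 to compound 3 (0.22 log units; within the scatter). On that basis compound 3 is expected to give about 5000 nM in this assay, with a range of 1500 nM to 16000 nM to allow for the absence of any precedent for this change.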

Compound 3, half-maximal inhibitory concentration: 9800 nM
Estimate against measurement, compound 3: 2.0-fold (0.29 log units) below, within the range that was stated.
By their numbers in this assay, from the lowest: compounds 2, 1 and 3 (each within the scatter of the next, the first and the last beyond it).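

Taking the hydroxy off the six-membered aromatic ring of carbon only, with hydrogen in its place, gives the first step in this assay that lies beyond the scatter, a 3.3-fold higher number from compound 2 to compound 3 (0.51 log units; beyond the scatter), modest in size but separable on this read-out. The earlier pair varied only the group on the nitrogen and could not be separated, whereas this pair shows that the position does register and that, with 1-phenylethyl held constant, the compound carrying the hydroxy gives the stronger inhibition. This rests on a single pair, and nothing measured here accounts for the difference.

Still open, from the compounds shown here alone, is whether the hydroxy itself matters or whether another group on the same aromatic carbon, such as methoxy, fluorine or an amine, would keep the lower number. Also open, going by these compounds, is whether removing the hydroxy gives a similar step with the 4-methylphenyl group of compound 1 on the nitrogen, and how this position behaves when the ethyl ester is replaced by a carboxylic acid or an amide.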